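This account rests on a few compounds, and the source may have more. Where it says the series, first, only, none or still open, it means among the compounds named here.

Measured so far: compound 1 `Cc1cc(N2CC[C@@H](C)[C@@H](N(C)c3ncnc4[nH]ccc34)C2)n2nc(SCc3ccccc3)nc2n1` gives 13900 nM in a functional assay on HGC-27 cells (Homo sapiens) for inhibition, read by MTT assay, with a stated time of 72 h; a lower number here means a stronger inhibitor, a higher number a weaker inhibitor; compound 2 `Cc1cc(N2CC[C@@H](C)[C@@H](N(C)c3ncnc4[nH]ccc34)C2)n2nc(SCC3CCCCC3)nc2n1` gives 11500 nM in this assay.

Compound 1 stands with the highest of the two numbers, and its nearest neighbour is compound 2, reached by a 1.2-fold lower number from compound 1 to compound 2 (0.08 log units; within the scatter). Compound 3 `Cc1cc(N2CC[C@@H](C)[C@@H](N(C)c3ncnc4[nH]ccc34)C2)n2nc(SCc3ccc(F)c(Cl)c3)nc2n1` differs from compound 1 by 3-chloro-4-fluorophenyl in place of phenyl on a saturated chain carbon bound to a sulfur. Going by the values given here, no measured step varies the same part in the same way: the one step available, the exchange of a ring at the same position in going from compound 1 to compound 2, stayed within the scatter, so the series gives no sign that this position moves the number much. The expectation for compound 3 is therefore a small step, a 1.4-fold lower number from compound 1 to compound 3 (0.14 log units; within the scatter), or none beyond the scatter, in this assay. Compound 3 is estimated at 10000 nM, with a range from 4000 nM to 25000 nM.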

Compound 3, half-maximal inhibitory concentration: > 100000 nM
Compound 3 ended at the assay's limit; the forecaster's own chance of this, stated with the estimate: 5%; middle value at least 10-fold (1.00 log units) from the limit.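

In this assay the entry for compound 3, > 100000 nM, is a limit of the assay and not a number. It shows that the position on the saturated chain carbon bound to a sulfur is not indifferent: the exchange of phenyl for cyclohexyl stayed within the scatter, yet 3-chloro-4-fluorophenyl in place of phenyl gives an at least 7.1-fold higher number from compound 1 to compound 3 (0.85 log units; beyond the scatter), and in place of cyclohexyl it gives an at least 8.6-fold higher number from compound 2 to compound 3 (0.93 log units; beyond the scatter). The full size of both steps stays unknown, since they rest on a limit and only their lower bound can be read: the limit of > 100000 nM in this assay, at which 1 of the 3 values shown sits.

The compounds shown do not separate the two halogens, so it remains open whether 3-chlorophenyl alone or 4-fluorophenyl alone would give the same step. From the compounds shown here alone, it also remains open how a phenyl bearing a methoxy group or an amine would read at this position.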